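Adding a chloro to a slowly cleared benzyl compound

The source may report more compounds than this note shows. Statements on the series, on what has been measured and on what is new or still open speak of the compounds shown alone.

Measured in an in vitro ADME assay on microsomes from liver (Homo sapiens) for metabolic stability; a higher number here means faster removal of the compound, a lower number slower removal:
- Compound 1 (`Cc1ccccc1-n1c(C)nnc1C1CCN(c2ccccn2)CC1`) gives 33 mL.min-1.g-1
- Compound 2 (`Cc1nnc(C2CCN(c3ccccn3)CC2)n1Cc1ccccc1`) gives < 8 mL.min-1.g-1 (a limit of the assay, not a number)
- Compound 3 (`Cc1nnc(C2CCN(c3ccccn3)CC2)n1Cc1cccc(Cl)c1`) has not yet been measured

Compound 2 stands on (the limit of < 8 mL.min-1.g-1 in this assay, at which 1 of the 2 values shown sits), so only a limit is known for it. The next change is chloro in place of hydrogen on an aromatic carbon, which turns benzyl into 3-chlorobenzyl. Among the compounds with values here, one measured step bears on this, and only indirectly. That step, an at least 4.1-fold lower number from compound 1 to compound 2 (0.61 log units; beyond the scatter), lies beyond the scatter, but it exchanges the whole group on the aromatic nitrogen. Within the data shown here, no measured step adds a chloro, so the evidence is thin. A single added chloro is a smaller change than that exchange, so a small upward step in this assay is expected, possibly none beyond the scatter. The estimated step is an at least 1.3-fold higher number from compound 2 to compound 3 (0.13 log units; that floor lies within the scatter). For compound 3 the expected value is 11 mL.min-1.g-1, with an estimated range from 5 mL.min-1.g-1 to 25 mL.min-1.g-1.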

Compound 3, intrinsic clearance in microsomes: 29 mL.min-1.g-1
Beside the measured number, compound 3's estimate is 2.6-fold (0.42 log units) below it; the whole stated range lies below it.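

In this assay, a single chloro in place of hydrogen on an aromatic carbon of the benzyl group, which turns it into 3-chlorobenzyl, is enough for an at least 3.6-fold higher number from compound 2 to compound 3 (0.55 log units; beyond the scatter). The slower removal seen with plain benzyl therefore does not carry over to this close relative: exchanging 2-methylphenyl for 3-chlorobenzyl on the aromatic nitrogen amounts only to a 1.1-fold lower number from compound 1 to compound 3 (0.06 log units; within the scatter). On these data alone, the true size of the chloro step stays unknown, because compound 2 has only a limit and not a number: the limit of < 8 mL.min-1.g-1 in this assay, at which 1 of the 3 values shown sits.

As far as these compounds go, it remains open whether this jump belongs to chloro in particular or would also follow from a small group such as fluoro, methyl or methoxy on the same carbon. Also open, from the compounds shown here alone, is whether the place itself matters, since a chloro on another carbon of the benzyl group might give a different number, and which part of the molecule is actually being attacked when compound 3 is removed.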